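The source may hold more compounds than are shown below. What is called first, only, known or untested is meant among the compounds shown, and "the series" means these compounds.

Series notes. Of the compounds shown here, three have been measured in a functional assay on MIA PaCa-2 cells (Homo sapiens) for cytotoxicity, read by WST assay, with a stated time of 24 h; a lower number here means a stronger inhibitor, a higher number a weaker inhibitor. Compound 1 `N#C/C(=C\c1c[nH]c2cc(F)ccc12)C(=O)c1c[nH]c2ccccc12` gives 23500 nM in this assay. Compound 2 `COc1ccc2c(C(=O)/C(C#N)=C/c3c[nH]c4cc(F)ccc34)c[nH]c2c1`, which carries a methoxy group on its core, reaches only the limit of this assay, > 50000 nM, so no number is known for it. Compound 3 `COc1ccc2c(C(=O)/C(C#N)=C/c3cn(Cc4ccc(Cl)cc4)c4ccccc34)c[nH]c2c1` likewise sits at a limit in this assay, > 50000 nM, and no number is known for it either.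

Among the measured compounds shown here, the one counted change among the measured pairs is hydrogen in place of methoxy on an aromatic carbon. It produced an at least 2.1-fold lower number from compound 2 to compound 1 (0.32 log units; beyond the scatter), a step whose true size is only bounded, since (the limit of > 50000 nM in this assay, at which 2 of the 3 values shown sit). The cores of compound 2 and compound 3 differ by more than a single change, and the difference between the two cores is not broken down here.

Compound 4 `N#C/C(=C\c1cn(Cc2ccc(Cl)cc2)c2ccccc12)C(=O)c1c[nH]c2ccccc12` has not yet been measured in this assay. For the measured compounds named here, its relation to compound 3 is hydrogen in place of methoxy on an aromatic carbon, the same change as the one from compound 2 to compound 1, at the same place: a six-membered aromatic ring of carbon only, part of a fused or bridged system of two rings, meta and para to a fused ring. Drawing on the earlier step, an at least 2.1-fold lower number from compound 2 to compound 1 (0.32 log units; beyond the scatter), the expected step from compound 3 to compound 4 in this assay is estimated as an at least 1.4-fold lower number from compound 3 to compound 4 (0.15 log units; that floor lies within the scatter). That expectation rests on compound 2 and compound 1 alone, and the starting point for compound 3 is a limit, so its size is uncertain. Compound 4 is expected to give about 35000 nM in this assay, with the estimate spanning 12000 nM to 100000 nM, and a limit remains a real possibility.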

Compound 4, half-maximal inhibitory concentration: > 50000 nM
Compound 4: a limit, no number; the forecaster's own chance of this, stated with the estimate: 40%; at least 1.4-fold (0.15 log units) between middle value and limit.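

In this assay compound 4 gives > 50000 nM, which is a limit and not a number. Compound 3 also sits at a limit, so no step from compound 3 to compound 4 can be read: the limit of > 50000 nM in this assay, at which 3 of the 4 values shown sit.

Going by these compounds, it remains open whether hydrogen in place of methoxy on an aromatic carbon changes the number at all in the core shared by compound 3 and compound 4.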